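Moving the fluorine and adding a methoxy on the anilide ring

The compounds below may be only part of what the source reports. "The series", "measured", "known", "first", "only" and "open" are said of these compounds alone.

In a functional assay on the whole organism (strain C57BL/6) for inhibition, with Mus musculus as the target, read by paw edema, with stated times of 1 h and 4 h, at a dose of 100 mg/kg by the oral route (on this read-out lower numbers stand for less inhibition and higher numbers for more inhibition at the one dose given (going by the name of the read-out)), compound 1 `CC(=O)Nc1ccc(Cc2noc(CCC(=O)Nc3ccccc3)n2)cc1` gives 34.2%, while compound 2 `CC(=O)Nc1ccc(Cc2noc(CCC(=O)Nc3ccccc3F)n2)cc1` gives 67.1%, the higher of the two numbers, with a number 32.9 percentage points higher from compound 1 to compound 2 (beyond the scatter). Compound 3 `COc1ccc(NC(=O)CCc2nc(Cc3ccc(NC(C)=O)cc3)no2)cc1F` differs from compound 2 by 3-fluoro-4-methoxyphenyl in place of 2-fluorophenyl on an amide-type nitrogen. Among the measured compounds shown here, only one measured step exists, the fluorine addition from compound 1 to compound 2, and it does not concern a 3-fluoro-4-methoxyphenyl group, so no step beyond the scatter is expected here. Compound 3 is therefore estimated at 60% in this assay, between 40% and 78%, an expected step of a number 7.1 percentage points lower from compound 2 to compound 3 (within the scatter).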

Compound 3, a percentage reported as inhibition, in the whole organism at one dose (the size of the read-out at that dose, not a potency): 60.3%
Compound 3: the middle estimate sits 0.3 percentage points below what was measured; the range from low to high includes it.
By their numbers in this assay, from the lowest: compound 1; then compounds 3 and 2 (each within the scatter of the next).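

On the amide-type nitrogen, 3-fluoro-4-methoxyphenyl in place of 2-fluorophenyl gives a number 6.8 percentage points lower from compound 2 to compound 3 (within the scatter) and so shows that the higher level does not depend on the 2-fluorophenyl group alone. Set against the plain phenyl, the same group gives a number 26.1 percentage points higher from compound 1 to compound 3 (beyond the scatter) and so confirms a second substituted ring that lifts the number. Nothing available explains how this position responds. The fluorine shift and the added methoxy arrive together, so their separate shares remain unresolved. On these data alone, whether a carboxylic acid or a dimethylamino group on this ring would hold the level also stays open.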